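Chloro to Bromo on the Aryl Ring of Compound 1

This account rests on a few compounds, and the source may have more. Where it says the series, first, only, none or still open, it means among the compounds named here.

Measured compounds:
compound 1 `COc1cccc(C2=CC(c3ccc(Cl)cc3)NC(=S)N2)c1`: 150 nM
compound 2 `COc1ccc(C2=NN(c3ccccc3)C(c3ccc(F)cc3)C2O)cc1`: 16 nM

Of the compounds shown here, two have been tested in a functional assay on MCF7 cells (Homo sapiens) for antiproliferative activity, read by sulforhodamine B assay, with a stated time of 48 h; on this read-out lower numbers stand for stronger inhibition and higher numbers for weaker inhibition. Compound 1 `COc1cccc(C2=CC(c3ccc(Cl)cc3)NC(=S)N2)c1` gives 150 nM, the highest of the two numbers, which here means the weaker growth inhibition. Compound 2 `COc1ccc(C2=NN(c3ccccc3)C(c3ccc(F)cc3)C2O)cc1`, built on a different core, gives 16 nM, a lower number that lies beyond the usual scatter of this assay. Within the data shown here, no step between these two is given, since they differ in more than one place, so their values are only read side by side.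

Compound 3 `COc1cccc(C2=CC(c3ccc(Br)cc3)NC(=S)N2)c1` has not yet been measured. It differs from compound 1 in a single spot: bromo in place of chloro on an aromatic carbon. The two halogens are exchanged on the same aromatic carbon, leaving the rest of the structure unchanged.

Among the measured compounds shown here, no measured pair shows this particular exchange. The step from compound 1 to compound 3 can only be guessed. Such a swap is expected to give a step of a 1.2-fold lower number from compound 1 to compound 3 (0.06 log units; within the scatter) in this assay, that is, a change of no more than the usual scatter in either direction. Compound 3 is therefore estimated at 130 nM, within a range of 60 nM to 300 nM.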

Compound 3, half-maximal inhibitory concentration: 135 nM
Beside the measured number, compound 3's estimate is 1.0-fold (0.02 log units) below it; measured number inside the range.
By their numbers in this assay, from the lowest: compound 2; then compounds 3 and 1 (each within the scatter of the next).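

In this assay, bromo in place of chloro on this aromatic carbon gives a 1.1-fold lower number from compound 1 to compound 3 (0.05 log units; within the scatter), so 4-chlorophenyl and 4-bromophenyl cannot be told apart on this read-out. Among these compounds, this is the first direct reading at this position, as it isolates a single change on the shared core, and it shows that one of these halogens can take the place of the other without moving the number beyond the usual scatter. No measurement is at hand that would explain this result.

Among the compounds shown here, the step covers only this one exchange between two halogens, so it remains open how the number would respond to a group of another kind on the same aromatic carbon, such as a hydroxyl, an amine or a carboxylic acid. On these data alone, it also rests on a single core in a single cell line, so whether the same exchange would read the same way on another core or in other cells is still unknown.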